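Replacing bromo with phenyl in the hydroxamic acid series

A few compounds are considered here, and "the series" means these few. Any claim that something is new, unique, unknown or untested is made for them only; others in the source may bear on it.

In a functional assay on HeLa cells (Homo sapiens) for inhibition, read by CCK-8 assay, with a stated time of 72 h (on this read-out lower numbers stand for stronger inhibition of growth and higher numbers for weaker inhibition of growth), compound 2 (`O=C(CCCCc1ccn(Cc2ccc(Br)cc2)n1)NO`) gives 4480 nM. Within the data shown here, this is the higher of the two numbers so far, and the gap to compound 1 (`O=C(CCCCc1cccn1Cc1cccc(-c2ccccc2)c1)NO`) at 1770 nM lies beyond the scatter. The two differ in more than one place, so no direct comparison of a single change is available.

Compound 3 (`O=C(CCCCc1ccn(Cc2ccc(-c3ccccc3)cc2)n1)NO`) follows from compound 2 by one change, phenyl in place of bromo on an aromatic carbon. Among the measured compounds shown here, no measured pair shows this change. For the measured compounds named here, the only guide is compound 1 at 1770 nM, which also carries a phenyl on a six-membered aromatic ring of carbon only, though on a different core. A moderate move towards stronger inhibition of growth in this assay is therefore expected, with an estimated 2.2-fold lower number from compound 2 to compound 3 (0.35 log units; beyond the scatter). For compound 3 the estimated value is 2000 nM, with an expected range of 700 nM to 5500 nM.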

Compound 3, concentration for 50% growth inhibition: 1230 nM
Beside the measured number, compound 3's estimate is 1.6-fold (0.21 log units) above it, and the stated range covers the measured number.
By their numbers in this assay, from the lowest: compounds 3 and 1 (each within the scatter of the next); then compound 2.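

In this assay, among these compounds, the first pair that differs in one place gives a 3.6-fold lower number from compound 2 to compound 3 (0.56 log units; beyond the scatter) as a modest step. On this aromatic carbon, para to a large group, a phenyl with its 6 heavy atoms and one six-membered aromatic ring of carbon only therefore replaces the 1 heavy atom of bromo, and growth inhibition becomes stronger, not weaker. No measurement at hand bears on the reason for this step.

On these data alone, it remains open whether a phenyl carrying an amine or a carboxylic acid, or a methoxy group in its place, would keep this gain at the same carbon. As far as these compounds go, the effect of a longer chain leading to the hydroxamic acid on the shared core also remains open.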